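The compounds below may be only part of what the source reports. "The series", "measured", "known", "first", "only" and "open" are said of these compounds alone.

Measured so far:

- compound 1, `COc1ccc2nc(C)cc(OC(C)C(=O)Nc3cc(C)cc(C)c3)c2c1`: in a physicochemical assay for solubility, in phosphate buffer, measured as kinetic solubility, with a stated time of 1 h, at pH 7.4 (a lower number here means a less soluble compound, a higher number a more soluble compound), compound 1 gives 61000 nM
- compound 2, `COc1ccc2nc(C)cc(OCC(=O)Nc3cccc(C)c3)c2c1`: in this assay compound 2 gives 193000 nM

Of the two numbers shown, compound 2 has the higher one; its gap to compound 1 is beyond the usual scatter of repeated measurements, so compound 2 is the more soluble of the pair as measured. For the measured compounds named here, the two compounds differ in more than one place, so no single step between them is counted here.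

The next compound, compound 3, `COc1ccc2nc(C)cc(OCC(=O)Nc3cccnc3)c2c1`, has not yet been measured in this assay. It is reached from compound 2 by one change: pyridin-3-yl in place of 3-methylphenyl on an amide-type nitrogen. The rest of the shared core and the linking amide are unchanged.

Going by the values given here, no measured step in this assay covers this kind of exchange, so the expectation rests on compound 2 alone and on the nature of the change. A step upward is expected, beyond the scatter, of the size a 2.3-fold higher number from compound 2 to compound 3 (0.37 log units; beyond the scatter). For compound 3 the estimated solubility in this assay is 450000 nM, with a range from 180000 nM to 1100000 nM.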

Compound 3, solubility: 32000 nM
Estimate against measurement, compound 3: 14-fold (1.15 log units) above, outside the stated range (below it).
By their numbers in this assay, from the lowest: compounds 3 and 1 (each within the scatter of the next); then compound 2.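

In this assay the group on the amide-type nitrogen proves to be a position where a single exchange registers clearly: pyridin-3-yl in place of 3-methylphenyl gives a 6.0-fold lower number from compound 2 to compound 3 (0.78 log units; beyond the scatter) and this step lies beyond the scatter. The exchange brings in a ring nitrogen and one hydrogen-bond acceptor and takes out the methyl, yet the number falls, so in this pair a hetero atom in the ring does not go with a higher solubility read-out. For the compounds shown here, this is the only single-place step in the set, and no supporting measurement is available to explain its direction or size.

The step leaves open how much of the fall goes with the ring nitrogen and how much with the lost methyl, as the two change together in this pair. An unsubstituted phenyl, a methyl-bearing pyridin-3-yl, pyridin-2-yl and pyridin-4-yl on the same amide-type nitrogen remain outside the compounds shown, as does any aromatic ring there carrying an amine or a carboxylic acid, so neither the separate contributions nor the reach of this trend can be read yet.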